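Thiophen-2-yl in place of neopentyl: what to expect

This account rests on a few compounds, and the source may have more. Where it says the series, first, only, none or still open, it means among the compounds named here.

Measured so far in an ADME assay on Caco-2 cells (Homo sapiens) for permeability, in the apical to basolateral direction; a lower number here means that the compound crosses the layer more slowly, a higher number that the compound crosses the layer faster:
compound 1 `CCC(=O)N1CCC(CN(C2Cc3cc(C#N)ccc3N(Cc3cncn3C)C2)S(=O)(=O)c2ccccn2)CC1`: 0.5 10^-6 cm/s
compound 2 `Cn1cncc1CN1CC(N(CC2CCN(C(=O)CC(C)(C)C)CC2)S(=O)(=O)c2ccccn2)Cc2cc(C#N)ccc21`: 0.5 10^-6 cm/s
compound 3 `Cn1cnc(S(=O)(=O)N(Cc2cccc(-n3cccc3)c2)C2Cc3cc(C#N)ccc3N(Cc3cncn3C)C2)c1`: 0.2 10^-6 cm/s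

Compound 2 stands level with compound 1 at the digits shown, and together they give the highest of the three numbers; compound 3 gives the lowest. Compound 4 `Cn1cncc1CN1CC(N(CC2CCN(C(=O)c3cccs3)CC2)S(=O)(=O)c2ccccn2)Cc2cc(C#N)ccc21` differs from compound 2 in one place: thiophen-2-yl in place of neopentyl on a carbonyl carbon. Among the compounds with values here, the only measured step that touches the same carbonyl carbon is no change at the digits printed from compound 1 to compound 2 (within the scatter), which changed the size of a saturated chain and left the number unmoved. Within the data shown here, no measured step exchanges a chain for an aromatic ring, so the evidence is thin. On that basis the step of no change at the digits printed from compound 2 to compound 4 (within the scatter) is expected to stay within the scatter. Compound 4 is therefore estimated at 0.5 10^-6 cm/s, with a range from 0.25 10^-6 cm/s to 1 10^-6 cm/s.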

Compound 4, apparent permeability: 0.5 10^-6 cm/s
The estimate for compound 4 equals the measured number at the digits printed, and the stated range covers the measured number.
By their numbers in this assay, from the lowest: compound 3; then compounds 1, 2 and 4 (each within the scatter of the next).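

Only saturated chains had been compared on this carbonyl carbon, and thiophen-2-yl now puts an aromatic ring there. In this assay, the change reads no change at the digits printed from compound 2 to compound 4 (within the scatter) when it replaces neopentyl and no change at the digits printed from compound 1 to compound 4 (within the scatter) when it replaces ethyl. Among these compounds, then, a chain and a five-membered aromatic ring with one hetero atom give the same reading at this position. On these data alone, whether a phenyl ring or a chain ending in an amine or a carboxylic acid would also leave the number unmoved stays open. Nothing available here offers an explanation for this result.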